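The compounds below may be only part of what the source reports. "The series", "measured", "known", "first", "only" and "open" are said of these compounds alone.

Of the compounds shown here, three sharing one core have been measured in a functional assay on PC-3 cells (Homo sapiens) for inhibition; a lower number here means a stronger inhibitor, a higher number a weaker inhibitor. Compound 1 `Cc1c(C(=O)N/N=C\c2ccc(O)c(O)c2O)oc2cccc(O)c12` gives >= 40000 nM in this assay, and that figure is a limit of the assay rather than a number. Compound 2 `Cc1c(C(=O)N/N=C\c2cccc(Br)c2O)oc2cccc(O)c12` gives 16600 nM. Compound 3 `Cc1c(C(=O)N/N=C\c2ccc(F)cc2)oc2cccc(O)c12` gives >= 40000 nM, again a limit of the assay. For the measured compounds named here, compound 3 therefore stands at the weak end of what has been measured: the one step that leads to it, an at least 2.4-fold higher number from compound 2 to compound 3 (0.38 log units; beyond the scatter), points toward weaker inhibition, and compound 3 sits at the limit of >= 40000 nM in this assay, at which 2 of the 3 values shown sit, together with compound 1.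

Compound 4 `Cc1c(C(=O)N/N=C\c2ccc(O)cc2O)oc2cccc(O)c12` differs from compound 3 in one place: 2,4-dihydroxyphenyl in place of 4-fluorophenyl on a carbon with a double bond to nitrogen. Going by the values given here, the only measured step touching this position, an at least 2.4-fold higher number from compound 2 to compound 3 (0.38 log units; beyond the scatter), shows that a hydroxy-bearing ring can be stronger than the 4-fluorophenyl, while compound 1, the other hydroxy-bearing analogue, gives >= 40000 nM, a limit. The data thus allow a modest gain or none at all. Compound 4 is expected to give about 35000 nM, between 12000 nM and 100000 nM, quite possibly as another limit. That estimate means a step of an at least 1.1-fold lower number from compound 3 to compound 4 (0.05 log units; that floor lies within the scatter), which stays within the scatter.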

Compound 4, half-maximal inhibitory concentration: 14800 nM
The estimate for compound 4 lay 2.4-fold (0.37 log units) above the measured number, within the range that was stated.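

Putting 2,4-dihydroxyphenyl in place of 4-fluorophenyl gives an at least 2.7-fold lower number from compound 3 to compound 4 (0.43 log units; beyond the scatter), and hydrogen in place of hydroxy on an aromatic carbon gives an at least 2.7-fold lower number from compound 1 to compound 4 (0.43 log units; beyond the scatter), so the ring on this carbon with a double bond to nitrogen does affect inhibition, and adding a hydroxy does not always help. Replacing 3-bromo-2-hydroxyphenyl with 2,4-dihydroxyphenyl gives a 1.1-fold lower number from compound 2 to compound 4 (0.05 log units; within the scatter), so these two rings cannot be told apart here, and two different hydroxy-bearing rings now give measurable numbers. Compound 1 and compound 3 remain at a limit of the assay, not at a number: the limit of >= 40000 nM in this assay, at which 2 of the 4 values shown sit.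

The compounds shown leave open which of the two hydroxy groups of compound 4 carries the gain. They also leave open whether an amine or a carboxylic acid on the same ring would match it.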